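Permeability notes: trifluoromethoxy in place of cyano

This account rests on a few compounds, and the source may have more. Where it says the series, first, only, none or still open, it means among the compounds named here.

compound 1 `N#Cc1c(-c2ccc(OCC3CCOC3)c(OC(F)(F)F)c2)nc(N)[nH]c1=O` gives 0.1 10^-6 cm/s
compound 2 `N#Cc1cc(-c2nc(N)[nH]c(=O)c2Cl)ccc1OCC1CCOC1` gives 0.2 10^-6 cm/s

In an ADME assay on Caco-2 cells (Homo sapiens) for permeability (a lower number here means that the compound crosses the layer more slowly, a higher number that the compound crosses the layer faster), compound 2 (0.2 10^-6 cm/s) stands within the usual scatter of compound 1 (0.1 10^-6 cm/s). Compound 3 `Nc1nc(-c2ccc(OCC3CCOC3)c(OC(F)(F)F)c2)c(Cl)c(=O)[nH]1` is not yet measured. Going by the values given here, it differs from compound 2 by trifluoromethoxy in place of cyano on an aromatic carbon and no step shows this change directly. With only those two close values to go on, no step beyond the scatter is expected in this assay here. An estimated 1.3-fold lower number from compound 2 to compound 3 (0.12 log units; within the scatter) would stay within the scatter. In this assay compound 3 is expected at 0.15 10^-6 cm/s (range 0.07 10^-6 cm/s to 0.4 10^-6 cm/s).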

Compound 3, apparent permeability: 6.4 10^-6 cm/s
The estimate for compound 3 lay 43-fold (1.63 log units) below the measured number; measured number above the stated range.
By their numbers in this assay, from the lowest: compounds 1 and 2 (each within the scatter of the next); then compound 3.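

In this assay, trifluoromethoxy in place of cyano on an aromatic carbon, ortho to the (oxolan-3-yl)methoxy group, gives a 32-fold higher number from compound 2 to compound 3 (1.51 log units; beyond the scatter). Chloro in place of cyano on an aromatic carbon gives a 64-fold higher number from compound 1 to compound 3 (1.81 log units; beyond the scatter). Compound 1 and compound 2 each keep one cyano group, compound 3 has none, and only compound 3 stands apart from the others.

Nothing available gives a reason for these steps. From the compounds shown here alone, whether a methoxy group or a single fluorine on that same aromatic carbon would match trifluoromethoxy remains open.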